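Replacing 1-carbamoylcyclopentyl with 3-acetamidopropyl

The source may report more compounds than this note shows. Statements on the series, on what has been measured and on what is new or still open speak of the compounds shown alone.

Values in an ADME assay on CEM-SS cells (Homo sapiens) for cytotoxicity, read by XTT assay, with a stated time of 6 days; on this read-out lower numbers stand for higher toxicity in this test and higher numbers for lower toxicity in this test:
Compound 1 `CCCC(=O)OCSc1ccc(OC)cc1C(=O)NCCC(N)=O`: > 100 uM (a limit)
Compound 2 `CCCC(=O)OCSc1ccccc1C(=O)NC1(C(N)=O)CCCC1`: > 100 uM (a limit)
Compound 3 `CCCC(=O)OCSc1ccccc1C(=O)NCCCCCC(N)=O`: 16.3 uM

Compound 2 gives > 100 uM, which is a limit of the assay and not a number. Compound 1 gives > 100 uM, which is also a limit. Compound 2 therefore stands at the limit of > 100 uM in this assay, at which 2 of the 3 values shown sit. Only compound 3 gives a number, 16.3 uM.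

Compound 4 `CCCC(=O)OCSc1ccccc1C(=O)NCCCNC(C)=O` has not yet been measured. It differs from compound 2 in one place, on an amide-type nitrogen: 3-acetamidopropyl in place of 1-carbamoylcyclopentyl on an amide-type nitrogen. In words, 3-acetamidopropyl comes in place of 1-carbamoylcyclopentyl, and the five-membered ring of carbon goes.

Among the compounds with values here, the one measured step that bears on this change is an at least 6.1-fold lower number from compound 2 to compound 3 (0.78 log units; beyond the scatter), where 5-carbamoylpentyl replaces the same group on the same nitrogen. That step lies beyond the scatter, and as it starts from a limit it gives only a minimum size. Compound 1 goes against a simple reading: it has no such ring either, yet it remains at the limit, though it also differs from compound 2 elsewhere. A lower number is therefore expected, probably by a smaller margin than in the measured step, and the assay may again report only a limit. The expected step is an at least 2.0-fold lower number from compound 2 to compound 4 (0.30 log units; that floor lies within the scatter). For compound 4 the estimated value is 50 uM, with an expected range from 15 uM to 150 uM.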

Compound 4, half-maximal toxic concentration: 21.1 uM
Compound 4: middle estimate off by 2.4-fold (0.37 log units), on the high side; the measured number falls inside the stated range.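

With this result, a second open-chain group on the amide-type nitrogen moves away from compound 2 in this assay, with an at least 4.7-fold lower number from compound 2 to compound 4 (0.67 log units; beyond the scatter), so the earlier step no longer stands alone; among the compounds that differ from compound 2 in one place, both lack the five-membered ring of carbon, while compound 1 also lacks that ring and goes against the pattern, though it differs from compound 2 in more than one place. Within the data shown here, the comparison of the two open chains adds what the earlier compounds could not show: with acetamido in place of 2-carbamoylethyl on a saturated chain carbon, three bonds along the chain from an amide-type nitrogen, there is a 1.3-fold higher number from compound 3 to compound 4 (0.11 log units; within the scatter), so these two chains cannot be told apart in this assay. The step from compound 2 gives only a minimum size because compound 2 stands at a limit: the limit of > 100 uM in this assay, at which 2 of the 4 values shown sit.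

The compounds shown leave open whether the loss of the ring or the chain itself goes with the lower numbers. They also leave open how a shorter chain such as 2-acetamidoethyl, or a chain ending in an amine or a carboxylic acid, would read in this assay.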